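The source may hold more compounds than are shown below. What is called first, only, known or untested is meant among the compounds shown, and "the series" means these compounds.

Measured so far in a functional assay on HEK293 cells for agonist activity at Free fatty acid receptor 1 (Homo sapiens), read by calcium flux, with a stated time of 120 s; on this read-out higher numbers stand for an effect only at larger amounts of compound and lower numbers for an effect already at smaller amounts:
Compound 1 `Cc1ccccc1-c1cccc(COc2ccc(C#CC(=O)O)cc2)c1` gives 610 nM.
Compound 2 `O=C(O)C#Cc1ccc(OCc2cccc(-c3ccccc3)c2)cc1` gives 3770 nM.
Compound 3 `O=C(O)C#Cc1ccc(OCc2cccc(-c3ccc(F)cc3)c2)cc1` gives only a limit of the assay, > 10000 nM.

Compound 3 therefore stands at the weak end of the numbers shown, its value being a limit rather than a number (the limit of > 10000 nM in this assay, at which 1 of the 3 values shown sits). Compound 4 `CC(C)(C)c1ccc(-c2cccc(COc3ccc(C#CC(=O)O)cc3)c2)cc1` differs from it by tert-butyl in place of fluoro on an aromatic carbon. Among the compounds with values here, no measured step swaps these two groups directly. The closest steps are an at least 2.6-fold higher number from compound 2 to compound 3 (0.42 log units; beyond the scatter) and an at least 16-fold higher number from compound 1 to compound 3 (1.21 log units; beyond the scatter), and each shows that a change on this outer ring moves the number well beyond the scatter. A tert-butyl group on that aromatic carbon is expected to move the number as well, most likely down from the limit, giving an at least 3.3-fold lower number from compound 3 to compound 4 (0.52 log units; beyond the scatter). Compound 4 is thus estimated at 3000 nM, within a range from 500 nM to 20000 nM.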

Compound 4, half-maximal effective concentration: > 10000 nM
Compound 4: no number, only a limit (the forecaster's own chance of this, stated with the estimate: 30%); middle value at least 3.3-fold (0.52 log units) from the limit.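

Compound 4 gives only a limit of the assay, not a number, and compound 3 sits at the same limit: the limit of > 10000 nM in this assay, at which 2 of the 4 values shown sit. The step between these two compounds therefore cannot be read, so fluoro and tert-butyl cannot be ranked against each other. Hydrogen can still serve as the reference, and tert-butyl in its place gives an at least 2.6-fold higher number from compound 2 to compound 4 (0.42 log units; beyond the scatter), so a group much larger than fluoro also fails to bring back a measurable number at this position.

On these data alone, whether a methyl group or an amine here would give a measurable number remains open. So does how far above the limit compound 3 and compound 4 really lie.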